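Working notes: the step from compound 2 to compound 3

The compounds below may be only part of what the source reports. "The series", "measured", "known", "first", "only" and "open" are said of these compounds alone.

In an ADME assay on HEK293 cells (Homo sapiens) for cytotoxicity, with a stated time of 72 h (a lower number here means that less compound is needed, a higher number that more compound is needed for the effect), compound 1 `Cc1cc(NC(=O)Nc2ccc(F)cc2F)c2ccccc2n1` gives 10000 nM. Compound 2 `Cc1cc(NC(=O)Nc2ncccc2C)c2ccccc2n1` gives > 25000 nM, which is a limit of the assay and not a number; the limit of > 25000 nM in this assay, at which 1 of the 2 values shown sits, is the only such case so far. Compound 3 `Cc1cc(NC(=O)Nc2ccccc2F)c2ccccc2n1` carries 2-fluorophenyl in place of 3-methylpyridin-2-yl on an amide-type nitrogen. Among the compounds with values here, no measured single-change step is available, so the expectation leans on compound 1 at 10000 nM, which also bears a fluorinated phenyl. The expected at least 1.5-fold lower number from compound 2 to compound 3 (0.19 log units; that floor lies within the scatter) is modest, toward a lower number. Compound 3 is estimated at 16000 nM, with a range of 7000 nM to 30000 nM.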

Compound 3, half-maximal effective concentration: > 25000 nM
Compound 3 gave a limit, no number; the forecaster's own chance of this, stated with the estimate: 30%; middle value at least 1.5-fold (0.19 log units) from the limit.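

In this assay, within the data shown here, hydrogen in place of fluoro on an aromatic carbon gives an at least 2.5-fold higher number from compound 1 to compound 3 (0.39 log units; beyond the scatter), the first readable single-change step, so the number at this ring responds to one fluoro. The change from 3-methylpyridin-2-yl to 2-fluorophenyl cannot be read, because compound 2 and compound 3 both give only a limit of the assay, not a number: the limit of > 25000 nM in this assay, at which 2 of the 3 values shown sit.

Going by these compounds, the full size of the step from compound 1 remains open. So does whether chloro or methoxy on that aromatic carbon would give a number like that of compound 1.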